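The compounds below may be only part of what the source reports. "The series", "measured", "known", "first", "only" and "open" are said of these compounds alone.

In a functional assay (aorta) for inhibition, with Oryctolagus cuniculus as the target (on this read-out lower numbers stand for stronger inhibition and higher numbers for weaker inhibition), compound 1 (`CCOC(=O)C1=C(C)N=C(S)NC1c1cccc([N+](=O)[O-])c1`) is reported only as a limit of the assay, > 1000 nM. Within the data shown here, compound 2 (`CCO/C(O)=C1\C(C)=NC(=S)N(C(=O)OC2CCN(Cc3ccccc3)CC2)C1c1ccccc1C(F)(F)F`) gives 9 nM, the only exact number available so far. Compound 3 (`CC1=NC(=S)N(C(=O)OC2CCN(Cc3ccccc3)CC2)C(c2ccccc2C(F)(F)F)/C1=C(\O)OC(C)C`) differs from compound 2 in one place, where ethoxy becomes isopropoxy: methyl in place of hydrogen on a saturated chain carbon bound to an oxygen on an unsaturated carbon and a saturated chain carbon. Among the measured compounds shown here, no measured pair shows what this change does. The expected step of a 1.3-fold higher number from compound 2 to compound 3 (0.12 log units; within the scatter) is small, within the usual scatter of this assay, with only a slight lean towards weaker inhibition. For compound 3 the estimated value is 12 nM, with an expected range of 3 nM to 50 nM.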

Compound 3, half-maximal inhibitory concentration: 5 nM
Compound 3: middle estimate off by 2.4-fold (0.38 log units), on the high side, and the stated range covers the measured number.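

In this assay the change from ethoxy to isopropoxy now has a measured step, a 1.8-fold lower number from compound 2 to compound 3 (0.26 log units; within the scatter), so the two compounds cannot be told apart at this position. Among these compounds, a single added methyl on this chain therefore leaves the read-out within its usual scatter, something the earlier compounds could not show. Nothing among the data shown accounts for this result.

Going by these compounds, what stays open is how much more this position accepts. A longer chain such as butoxy, a benzyloxy group or a chain ending in an amine would each test that further.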